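From a methoxy to a hydroxy on a shared core

The compounds below may be only part of what the source reports. "The series", "measured", "known", "first", "only" and "open" are said of these compounds alone.

compound 1 `COc1ccc2oc(=O)c(=O)[nH]c2c1` gives 15000 nM here
compound 2 `COc1ccc2[nH]c(=O)c(=O)oc2c1` gives 28000 nM here

Both values come from a functional assay with Rattus norvegicus as the target (on this read-out lower numbers stand for stronger inhibition and higher numbers for weaker inhibition), and lie within the usual scatter of each other, so compound 2 stands level with compound 1 and the two cannot be ranked. The next molecule is compound 3 `O=c1[nH]c2ccc(O)cc2oc1=O` and it differs from compound 2 in one place: hydrogen in place of methyl on an oxygen on an aromatic ring (hydrogen in place of methyl on an oxygen on an aromatic ring, or methoxy to hydroxy). Going by the values given here, no pair of measured compounds shows this change, so the data give no direct guide to its size or direction. Among the compounds with values here, the only anchor is compound 2 at 28000 nM and the expectation in this assay stays close to it, with no step beyond the scatter and no direction favoured. The estimated move is a 1.1-fold lower number from compound 2 to compound 3 (0.05 log units; within the scatter) and this is expected to be indistinguishable from repeat variation. With so little to go on, the range has to be wide. Compound 3 is thus estimated at 25000 nM within a range of 8000 nM to 80000 nM overall.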

Compound 3, half-maximal inhibitory concentration: 170000 nM
Beside the measured number, compound 3's estimate is 6.8-fold (0.83 log units) below it, and the stated range ends below it.
By their numbers in this assay, from the lowest: compounds 1 and 2 (each within the scatter of the next); then compound 3.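

In this assay, going by these compounds alone, the change from methoxy to hydroxy gives a 6.1-fold higher number from compound 2 to compound 3 (0.78 log units; beyond the scatter) and is the only step between measured compounds in this set, which makes it the first direct reading of what this position tolerates. In this single pair, the methyl on an oxygen on an aromatic ring is not a silent detail: removing it and leaving hydrogen in its place pushes the number upward, towards weaker inhibition. This step lies beyond the usual scatter of repeated measurements. The data give no measurement that could explain the size or direction of this step.

The compounds shown leave open whether a larger group on this oxygen, such as ethoxy, or a different group in the same place, such as an amine or a chlorine, would bring the number back down or raise it further. Within the data shown here, they also leave open whether the same change made on compound 1 would give a similar step, as this one pair is the only view of the change and no general rule can rest on it.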